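Trifluoromethyl for Methoxy in an Antiproliferative Series

The source may hold more compounds than are shown below. What is called first, only, known or untested is meant among the compounds shown, and "the series" means these compounds.

Three compounds have been measured in a functional assay on MDA-MB-231 cells (Homo sapiens) for antiproliferative activity, with a stated time of 4 days; a lower number here means a stronger inhibitor, a higher number a weaker inhibitor:

compound 1, `CCCCCCc1ccc2[nH]c(-c3ccc(OC)cc3)c(C=O)c2c1`, gives 7.4 nM
compound 2, `CCCCCCc1ccc2[nH]c(-c3ccc(C(F)(F)F)cc3)c(C=O)c2c1`, gives 43 nM
compound 3, `CCCCc1ccc2[nH]c(-c3ccc(OC)cc3)c(/C=N\O)c2c1`, gives 40 nM

Compound 2 differs from compound 1 by trifluoromethyl in place of methoxy on an aromatic carbon, and this change gave a 5.8-fold higher number from compound 1 to compound 2 (0.76 log units; beyond the scatter). Compound 3 shares its core with neither of these in a way that is broken down here; the difference between the core of compound 3 and the core of compound 1 is not broken down here. Its value in this assay lies close to that of compound 2, and the two are within the scatter of each other.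

Compound 4, `CCCCc1ccc2[nH]c(-c3ccc(C(F)(F)F)cc3)c(/C=N\O)c2c1`, differs from compound 3 by trifluoromethyl in place of methoxy on an aromatic carbon. The place of the change is described in the same words as for compound 1 and compound 2, so it is the same change made on a second core. Because a 5.8-fold higher number from compound 1 to compound 2 (0.76 log units; beyond the scatter) was a modest weakening beyond the scatter, a step of similar size is expected from compound 3 to compound 4, namely a 5.8-fold higher number from compound 3 to compound 4 (0.76 log units; beyond the scatter). On this basis compound 4 is estimated at 230 nM, with an expected range from 80 nM to 700 nM.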

Compound 4, half-maximal inhibitory concentration: 497 nM
Compound 4: middle estimate off by 2.2-fold (0.33 log units), on the low side, and the stated range covers the measured number.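

In this assay, trifluoromethyl in place of methoxy on the second core gave a 12-fold higher number from compound 3 to compound 4 (1.09 log units; beyond the scatter), so the change moved the number in the same direction on both cores shown. The two steps cannot be told apart, and the change carried over from one core to the other as a weakening of similar size: the same change on two cores in this assay, a 5.8-fold higher number (0.76 log units; beyond the scatter) from compound 1 to compound 2 and a 12-fold higher number (1.09 log units; beyond the scatter) from compound 3 to compound 4, 2.1-fold (0.33 log units) apart, within the scatter of two such steps. For the compounds shown here, this rests on only two pairs of compounds, however, so it does not show that the step would carry over to any other core, and it gives no reason for the weakening.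

The compounds shown leave open how other groups on the same aromatic carbon would compare with methoxy and trifluoromethyl, such as a fluorine, a methyl, a nitrile, an amine or a carboxylic acid. They also leave open whether the step would hold on a core with a chain longer than hexyl or with a group other than the aldehyde or the oxime.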